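Swapping a pyridinylmethyl for a fluorophenyl on the piperazine

This account rests on a few compounds, and the source may have more. Where it says the series, first, only, none or still open, it means among the compounds named here.

Measured compounds:
Compound 1, `Nc1ccccc1NC(=O)c1ccc(CSC(=S)N2CCN(Cc3ccccn3)CC2)cc1`: 20.7%
Compound 2, `Nc1ccccc1NC(=O)c1ccc(CSC(=S)N2CCN(c3ccccc3)CC2)cc1`: 27.5%
Compound 3, `Nc1ccccc1NC(=O)c1ccc(CSC(=S)N2CCN(Cc3cccnc3)CC2)cc1`: 31.5%

All three were tested in a functional assay on A-375 cells (Homo sapiens) for antiproliferative activity, read by CCK-8 assay, with a stated time of 72 h, tested at 2 uM; on this read-out higher numbers stand for a stronger effect at the one concentration tested and lower numbers for a weaker effect. Compound 3 stands beyond the scatter above compound 1 (a number 10.8 percentage points higher from compound 1 to compound 3 (beyond the scatter)) but within the scatter of compound 2 (a number 4 percentage points higher from compound 2 to compound 3 (within the scatter)). Compound 4, `Nc1ccccc1NC(=O)c1ccc(CSC(=S)N2CCN(c3ccccc3F)CC2)cc1`, has not been measured; it differs from compound 3 by 2-fluorophenyl in place of (pyridin-3-yl)methyl on an amine nitrogen in a ring. The step that bears most on this is the one from a phenyl to a (pyridin-3-yl)methyl group, a number 4 percentage points higher from compound 2 to compound 3 (within the scatter), which stayed within the scatter, as did a number 6.8 percentage points higher from compound 1 to compound 2 (within the scatter). Returning to an aromatic ring bound directly to the ring nitrogen is therefore expected to give no step beyond the scatter, a number 3.5 percentage points lower from compound 3 to compound 4 (within the scatter). Compound 4 is estimated at 28%, between 18% and 38%.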

Compound 4, a percentage reported as inhibition, at one concentration (the size of the read-out at that concentration, not a potency): 18.7%
Beside the measured number, compound 4's estimate is 9.3 percentage points above it; measured number inside the range.
By their numbers in this assay, from the lowest: compounds 4, 1, 2 and 3 (each within the scatter of the next, the first and the last beyond it).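

In this assay, adding fluoro in place of hydrogen on an aromatic carbon gives a number 8.8 percentage points lower from compound 2 to compound 4 (within the scatter), so this single change does not separate the two compounds. Exchanging (pyridin-3-yl)methyl for 2-fluorophenyl on the ring nitrogen gives a number 12.8 percentage points lower from compound 3 to compound 4 (beyond the scatter), whereas exchanging (pyridin-2-yl)methyl for it gives a number 2 percentage points lower from compound 1 to compound 4 (within the scatter), so the outcome depends on which group leaves. No measured evidence here explains these differences. As far as these compounds go, it remains open whether chloro or methoxy on the phenyl ring would give a step beyond the scatter.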